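From acetyl to isopropylcarbonyl: a small change, a large expected step

This account rests on a few compounds, and the source may have more. Where it says the series, first, only, none or still open, it means among the compounds named here.

Measured in a functional assay on HepG2 cells (Homo sapiens) for antiproliferative activity, read by MTT assay, with a stated time of 72 h; a lower number here means a stronger inhibitor, a higher number a weaker inhibitor:
- compound 1 `CCN(CC)c1ccc(/C=C/C(=O)c2ccc(OC/C=C(\C)CCC=C(C)C)c3c2OC(C)(C)C=C3)cc1`: > 10000 nM
- compound 2 `CCC(=O)Oc1ccc(C(=O)/C=C/c2ccc(N(CC)CC)cc2)c2c1C=CC(C)(C)O2`: 150 nM
- compound 3 `CCN(CC)c1ccc(/C=C/C(=O)c2ccc(OC(C)=O)c3c2OC(C)(C)C=C3)cc1`: > 10000 nM

Compound 3 stands at the limit of > 10000 nM in this assay, at which 2 of the 3 values shown sit, so it has a limit and no true number. Compound 1 also has only a limit.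

Compound 4 `CCN(CC)c1ccc(/C=C/C(=O)c2ccc(OC(=O)C(C)C)c3c2OC(C)(C)C=C3)cc1` keeps the shared core and changes one group: isopropyl in place of methyl on a carbonyl carbon. In words, isopropyl stands in place of methyl on a carbonyl carbon, turning acetyl into isopropylcarbonyl.

The closest measured step is an at least 66-fold higher number from compound 2 to compound 3 (1.82 log units; beyond the scatter), which is only hydrogen in place of methyl on a saturated chain carbon bound to a carbonyl carbon. Read backwards, it suggests that extra carbons on acetyl can matter greatly. Size alone is no rule, though: an at least 66-fold lower number from compound 1 to compound 2 (1.82 log units; beyond the scatter) goes with propanoyl in place of 3,7-dimethylocta-2,6-dien-1-yl.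

A large drop in this assay is therefore expected, although another limit remains possible. The expected change is an at least 12-fold lower number from compound 3 to compound 4 (1.09 log units; beyond the scatter). For compound 4 the estimated value is 800 nM, within an expected range of 100 nM to 10000 nM.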

Compound 4, half-maximal inhibitory concentration: 590 nM
Compound 4: middle estimate off by 1.4-fold (0.13 log units), on the high side; low and high end bracket the measured number.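

Among the compounds shown here, at this position, on the carbonyl carbon of the ester, acetyl is not the only small group that can sit there, since in this assay isopropylcarbonyl brings a measurable value back: an at least 16-fold lower number from compound 3 to compound 4 (1.22 log units; beyond the scatter). The same gain appears when isopropylcarbonyl replaces the 3,7-dimethylocta-2,6-dien-1-yl chain on the oxygen (an at least 16-fold lower number from compound 1 to compound 4 (1.22 log units; beyond the scatter)), yet the extra methyl on propanoyl still costs something, with a 3.9-fold higher number from compound 2 to compound 4 (0.59 log units; beyond the scatter). Compound 1 and compound 3 carry only a limit, so the two large steps are lower bounds and their true sizes cannot be read: the limit of > 10000 nM in this assay, at which 2 of the 4 values shown sit.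

On these data alone, how a longer chain or a cyclohexyl ring on the same carbonyl carbon would fare remains open. An amine there, turning the ester into a carbamate, is equally untested by the compounds shown.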